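The source may hold more compounds than are shown below. What is called first, only, known or untested is meant among the compounds shown, and "the series" means these compounds.

Measured compounds in a functional assay on MCF7 cells (Homo sapiens) for cytotoxicity, read by MTT assay, with a stated time of 72 h; on this read-out higher numbers stand for weaker inhibition and lower numbers for stronger inhibition:
Compound 1 `O=C(Nc1ccc(Oc2ccnc3[nH]ccc23)cc1)c1nn(-c2ccccc2)ccc1=O` gives 15600 nM.
Compound 2 `Cn1ccc2c(Oc3ccc(NC(=O)c4nn(-c5ccc(Cl)cc5)ccc4=O)cc3)ccnc21` gives only a limit of the assay, > 60000 nM.
Compound 3 `Cn1ccc2c(Oc3ccc(NC(=O)c4nn(-c5ccc(Br)cc5)ccc4=O)cc3)ccnc21` gives 16300 nM.

Of the two numbers shown in this assay, compound 3 carries the higher one; its nearest neighbour is compound 1, whose number sits within the scatter of that of compound 3, so no order between the two can be read. The value of compound 2 is a limit (the limit of > 60000 nM in this assay, at which 1 of the 3 values shown sits).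

Compound 4 `Cn1ccc2c(Oc3ccc(NC(=O)c4nn(-c5ccccc5)ccc4=O)cc3)ccnc21` differs from compound 3 by hydrogen in place of bromo on an aromatic carbon. For the measured compounds named here, one measured step touches the same aromatic carbon: an at least 3.6-fold lower number from compound 2 to compound 3 (0.56 log units; beyond the scatter). It is the only step shown and it runs between two halogens; no step from a halogen to hydrogen is measured in this assay. Compound 1, which carries the unsubstituted phenyl on a core lacking the methyl group, gives a number indistinguishable from that of compound 3. Going by the values given here, removing bromo is therefore expected to move the number little, with a wider spread allowed for the single halogen step, which was at least modest. The step from compound 3 to compound 4 is estimated as a 1.1-fold higher number from compound 3 to compound 4 (0.04 log units; within the scatter). Compound 4 is expected to give 18000 nM, with a range of 8000 nM to 45000 nM.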

Compound 4, half-maximal inhibitory concentration: 45200 nM
Compound 4: middle estimate off by 2.5-fold (0.40 log units), on the low side; measured number outside the range, above it.
By their numbers in this assay, from the lowest: compounds 1 and 3 (each within the scatter of the next); then compound 4. At a limit, above all of these: compound 2.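

In this assay the 4-bromophenyl to phenyl change now has a measured size (a 2.8-fold higher number from compound 3 to compound 4 (0.44 log units; beyond the scatter)), so on this carbon, on the six-membered aromatic ring of carbon only and para to a large group, hydrogen in place of bromo gives a modestly higher number. The methyl on the aromatic nitrogen also carries a step of its own (a 2.9-fold higher number from compound 1 to compound 4 (0.46 log units; beyond the scatter)), so the match between compound 1 and compound 3 joins two compounds that differ in two places and says nothing about phenyl and 4-bromophenyl being equal. The step from chloro to hydrogen is only a floor (an at least 1.3-fold lower number from compound 2 to compound 4 (0.12 log units; that floor lies within the scatter)), so it gives no order between the two. Compound 2 gives a limit and not a number: the limit of > 60000 nM in this assay, at which 1 of the 4 values shown sits.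

From the compounds shown here alone, whether the methyl step seen with phenyl holds unchanged with 4-bromophenyl stays open, as does the true place of chloro relative to hydrogen. Going by these compounds, whether a methoxy, a nitrile or an amine on the same carbon would fall with bromo or with hydrogen is also open.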